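Estimating a Carboxypyridyl Variant on a Shared Core

The source may hold more compounds than are shown below. What is called first, only, known or untested is meant among the compounds shown, and "the series" means these compounds.

Compound 1 `CCC(C)(C)Cc1c[nH]c(CCc2ccc(-c3csnn3)cc2)n1` gives 45 nM in an in vitro assay on CHO cells for displacement of a labelled ligand from Bombesin receptor subtype-3 (Homo sapiens), read by scintillation counting, with a stated time of 2 h; on this read-out lower numbers stand for stronger inhibition and higher numbers for weaker inhibition.
Compound 2 `CCC(C)(C)Cc1c[nH]c(CCc2ccc(-c3cnccn3)cc2)n1` gives 51 nM.
Compound 3 `CCC(C)(C)Cc1c[nH]c(CCc2ccc(-c3ccns3)cc2)n1` gives 11 nM.

Compound 2 has the highest number of the three measured; compound 1 sits nearest, with a 1.1-fold higher number from compound 1 to compound 2 (0.05 log units; within the scatter), while compound 3 lies furthest, with a 4.6-fold lower number from compound 2 to compound 3 (0.67 log units; beyond the scatter). Compound 4 `CCC(C)(C)Cc1c[nH]c(CCc2ccc(-c3cccnc3C(=O)O)cc2)n1` differs from compound 2 by 2-carboxypyridin-3-yl in place of pyrazin-2-yl on an aromatic carbon. Both measured steps from compound 2 swap the same aromatic substituent: one stayed within the scatter, the other was modest. Neither brings in a carboxylic acid, so they are only a loose guide. The expected step in this assay is small, a 1.6-fold higher number from compound 2 to compound 4 (0.20 log units; within the scatter), with wide uncertainty in either direction. Compound 4 is therefore estimated at 80 nM, within 25 nM to 250 nM.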

Compound 4, half-maximal inhibitory concentration: 560 nM
Compound 4: the middle estimate sits 7.0-fold (0.85 log units) below what was measured; measured number above the stated range.
By their numbers in this assay, from the lowest: compound 3; then compounds 1 and 2 (each within the scatter of the next); then compound 4.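

In this assay, the place on the aromatic ring of carbon only, para to a large group, turns out to be far less forgiving than the earlier swaps suggested: 2-carboxypyridin-3-yl gives an 11-fold higher number from compound 2 to compound 4 (1.04 log units; beyond the scatter), with a 12-fold higher number from compound 1 to compound 4 (1.09 log units; beyond the scatter) and a 51-fold higher number from compound 3 to compound 4 (1.71 log units; beyond the scatter) as well. Among the rings without a carboxylic acid, the steps had been modest at most, so this is the first large step seen here. Nothing measured here explains the loss.

As far as these compounds go, this single change brings in both a pyridine ring and a carboxylic acid, so which of the two matters remains open. A plain pyridin-3-yl, or a methyl ester or primary amide in place of the acid, would help separate them.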